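A benzoyl in place of an isopropylcarbonyl group

The source may report more compounds than this note shows. Statements on the series, on what has been measured and on what is new or still open speak of the compounds shown alone.

Of the compounds shown here, three have been measured in an assay on HEK293 cells for inhibition of acid ceramidase (Rattus norvegicus), read by LC-MS, with a stated time of 30 min; a higher number here means a weaker inhibitor, a lower number a stronger inhibitor. Compound 1 `CCCCCCNC(=O)n1cc(N(C)Cc2ccccc2)c(=O)[nH]c1=O` gives 5500 nM, compound 2 `CCCCCCNC(=O)n1cc(I)c(=O)[nH]c1=O` gives 147 nM, and compound 3 `CCCCCCNC(=O)n1cc(F)c(=O)n(C(=O)C(C)C)c1=O` gives 21 nM. Compound 3 therefore has the lowest number of the three; its gap to compound 2, the nearest, lies beyond the usual scatter, and so does its gap to compound 1. Compound 4 `CCCCCCNC(=O)n1cc(F)c(=O)n(C(=O)c2ccccc2)c1=O` differs from compound 3 in a single place: phenyl in place of isopropyl on a carbonyl carbon. Within the data shown here, no measured pair shows a change of this kind, so the size of the step cannot be read from existing data. The expected step of a 1.4-fold higher number from compound 3 to compound 4 (0.15 log units; within the scatter) is small, within the scatter, with no firm direction. Compound 4 is accordingly estimated at 30 nM, with a range from 8 nM to 120 nM.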

Compound 4, half-maximal inhibitory concentration: 20 nM
Estimate against measurement, compound 4: 1.5-fold (0.18 log units) above; low and high end bracket the measured number.
By their numbers in this assay, from the lowest: compounds 4 and 3 (each within the scatter of the next); then compound 2; then compound 1.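

Phenyl in place of isopropyl on a carbonyl carbon gives a 1.1-fold lower number from compound 3 to compound 4 (0.02 log units; within the scatter) and so leaves the number unchanged. Among these compounds, this is the first measured step at this position, and it shows that 6 heavy atoms in an aromatic ring serve as well here as the 3 heavy atoms of isopropyl. Nothing available explains this result.

On these data alone, how a longer chain or an amine on this carbonyl carbon would compare remains open. The effect of removing the whole isopropylcarbonyl or benzoyl group also cannot be read from these compounds.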